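Swapping Cyclohexyl for Phenyl on a Saturated Ring Carbon

A few compounds are considered here, and "the series" means these few. Any claim that something is new, unique, unknown or untested is made for them only; others in the source may bear on it.

Compound 1, `Cc1ccc(S(=O)(=O)N2CC=C(Cl)CC2)cc1`: > 100000 nM (a limit of the assay, not a number).
Compound 2, `CCCCCCCC1C=C(Cl)CCN1S(=O)(=O)c1ccc(C)cc1`: 49000 nM.
Compound 3, `Cc1ccc(S(=O)(=O)N2CCC(Cl)=CC2C2CCCCC2)cc1`: 62000 nM.

In a functional assay on SW1573 cells (Homo sapiens) for antiproliferative activity, read by sulforhodamine B assay, with a stated time of 48 h (a higher number here means a weaker inhibitor of growth, a lower number a stronger inhibitor of growth), compound 1 gives a value that is only a limit of the assay. Compound 2 and compound 3 carry a heptyl or a cyclohexyl group on the same ring carbon, and the difference between them, a 1.3-fold higher number from compound 2 to compound 3 (0.10 log units; within the scatter), lies within the scatter; compound 3 therefore stands level with compound 2. The steps of an at least 2.0-fold lower number from compound 1 to compound 2 (0.30 log units; that floor lies within the scatter) and an at least 1.6-fold lower number from compound 1 to compound 3 (0.20 log units; that floor lies within the scatter) start from a limit and set only floors. Compound 4, `Cc1ccc(S(=O)(=O)N2CCC(Cl)=CC2c2ccccc2)cc1`, differs from compound 3 by phenyl in place of cyclohexyl on a saturated ring carbon. Within the data shown here, no measured step exchanges cyclohexyl for phenyl, so no step beyond the scatter is expected, a 1.0-fold lower number from compound 3 to compound 4 (0.01 log units; within the scatter). Compound 4 is estimated at 60000 nM, between 20000 nM and 150000 nM.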

Compound 4, concentration for 50% growth inhibition: 16000 nM
The estimate for compound 4 lay 3.8-fold (0.57 log units) above the measured number; the whole stated range lies above it.
By their numbers in this assay, from the lowest: compound 4; then compounds 2 and 3 (each within the scatter of the next). At a limit, above all of these: compound 1.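

On this saturated ring carbon, next to the ring nitrogen, the nature of the six-membered ring matters in this assay: phenyl in place of cyclohexyl gives a 3.9-fold lower number from compound 3 to compound 4 (0.59 log units; beyond the scatter). Phenyl in place of heptyl gives a 3.1-fold lower number from compound 2 to compound 4 (0.49 log units; beyond the scatter), so phenyl stands apart from both saturated groups, which showed no such separation from each other. Starting from a limit, an at least 6.2-fold lower number from compound 1 to compound 4 (0.79 log units; beyond the scatter) sets only a floor, yet it is the one floor from that limit beyond the scatter: the limit of > 100000 nM in this assay, at which 1 of the 4 values shown sits.

From the compounds shown here alone, what a pyridine ring or a methoxy-bearing phenyl would do on this carbon stays open. So does whether the step from cyclohexyl to phenyl holds without the chloro group.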